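Carboxy to methoxycarbonyl: expected cytotoxicity step

This account rests on a few compounds, and the source may have more. Where it says the series, first, only, none or still open, it means among the compounds named here.

Compound 1 `COCc1c(C)coc1-c1ccc2c(c1OC)CCCC2(C)C` and compound 2 `CCOCc1c(C)coc1-c1ccc2c(c1OC)CCCC2(C)C` carry alkoxymethyl groups on the shared core, while compound 3 `COc1c(-c2occ(C)c2C(=O)O)ccc2c1CCCC2(C)C` carries a carboxy group there. In a functional assay on KBVIN cells (Homo sapiens) for cytotoxicity, read by sulforhodamine B assay, with a stated time of 3 days (on this read-out lower numbers stand for an effect already at smaller amounts and higher numbers for an effect only at larger amounts of compound), compound 1 gives 20.1 uM, compound 2 gives 16.5 uM and compound 3 gives 47.8 uM. Compound 3 stands highest of the three: a 2.4-fold higher number from compound 1 to compound 3 (0.38 log units; beyond the scatter) and a 2.9-fold higher number from compound 2 to compound 3 (0.46 log units; beyond the scatter), both modest but beyond the scatter, whereas a 1.2-fold lower number from compound 1 to compound 2 (0.09 log units; within the scatter) stays within it. Compound 4 `COC(=O)c1c(C)coc1-c1ccc2c(c1OC)CCCC2(C)C` differs from compound 3 by methyl in place of hydrogen on an oxygen next to a carbonyl group. Going by the values given here, no measured step covers this change directly; the only bearing evidence is that the carboxy compound returns the higher number against both ether-bearing compounds, with the ether chain length making no difference beyond the scatter. Removing the free carboxy hydrogen is therefore expected to bring the number back toward those of compounds 1 and 2. For compound 4 a modest lower number is expected, a 1.9-fold lower number from compound 3 to compound 4 (0.28 log units; within the scatter). Compound 4 is estimated at 25 uM in this assay, with a range of 10 uM to 60 uM.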

Compound 4, concentration for half-maximal effect: 52.1 uM
For compound 4 the middle estimate is 2.1-fold (0.32 log units) below the measured one; measured number inside the range.
By their numbers in this assay, from the lowest: compounds 2 and 1 (each within the scatter of the next); then compounds 3 and 4 (each within the scatter of the next).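

In this assay, methyl in place of hydrogen on an oxygen next to a carbonyl group gives a 1.1-fold higher number from compound 3 to compound 4 (0.04 log units; within the scatter), so carboxy and methoxycarbonyl are not separated at this aromatic carbon. Methoxycarbonyl also stands apart from the alkoxymethyl groups, with a 3.2-fold higher number from compound 2 to compound 4 (0.50 log units; beyond the scatter) and a 2.6-fold higher number from compound 1 to compound 4 (0.41 log units; beyond the scatter), so among the four compounds shown, the two with a carbonyl group at this carbon give the higher numbers, and no compound goes against this grouping. No measurement at hand offers a reason for this grouping.

On these data alone, whether the carbonyl group alone carries this grouping remains open, and an amide, a ketone or a hydroxymethyl group at this carbon would bear on that. As far as these compounds go, it is also open whether a longer ester chain than methoxycarbonyl would stay with compound 4 in this grouping.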